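This account rests on a few compounds, and the source may have more. Where it says the series, first, only, none or still open, it means among the compounds named here.

Two compounds share one core and differ only in the ring that sits on the amide nitrogen. Compound 1 `COc1ccc(NC(=O)/C=C/c2coc3cc(OC)ccc3c2=O)cc1` carries a 4-methoxyphenyl there. In a functional assay (QGY7701 cells, Homo sapiens) for inhibition, read by MTT assay, with a stated time of 48 h (on this read-out higher numbers stand for weaker inhibition and lower numbers for stronger inhibition), compound 1 reaches only the limit of the measurement, > 100000 nM, so no number is known for it. Compound 2 `COc1ccc2c(=O)c(/C=C/C(=O)Nc3ccccc3C)coc2c1` carries a 2-methylphenyl instead, and in this assay compound 2 gives 22500 nM. Among the compounds with values here, compound 2 thus holds the only measured number in the set; the other value is a limit. The step of an at least 4.4-fold lower number from compound 1 to compound 2 (0.64 log units; beyond the scatter) is beyond the scatter, though its full size stays hidden by the limit (the limit of > 100000 nM in this assay, at which 1 of the 2 values shown sits).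

Compound 3 `CCOc1ccc(NC(=O)/C=C/c2coc3cc(OC)ccc3c2=O)cc1` is not yet measured. It differs from compound 2 in one place: 4-ethoxyphenyl in place of 2-methylphenyl on an amide-type nitrogen. This largely undoes the earlier change, bringing back a ring of the kind found in compound 1, with an ethoxy rather than a methoxy group. Within the data shown here, since the only measured step of an at least 4.4-fold lower number from compound 1 to compound 2 (0.64 log units; beyond the scatter) ran toward a lower number when the 4-methoxyphenyl gave way to 2-methylphenyl, the reverse is expected to run toward a higher one, roughly a 3.1-fold higher number from compound 2 to compound 3 (0.49 log units; beyond the scatter). Compound 3 is therefore estimated at 70000 nM, with a likely range from 20000 nM to 250000 nM, and a real chance that this assay again reports only a limit.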

Compound 3, half-maximal inhibitory concentration: > 100000 nM
Compound 3 gave a limit, no number; the forecaster's own chance of this, stated with the estimate: 45%; middle value at least 1.4-fold (0.15 log units) away from the limit.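

Replacing the 2-methylphenyl on the amide-type nitrogen with a 4-ethoxyphenyl gives, in this assay, an at least 4.4-fold higher number from compound 2 to compound 3 (0.64 log units; beyond the scatter). The 4-methoxyphenyl of compound 1 and the 4-ethoxyphenyl of compound 3 therefore both fall on the same side of this comparison, and among these three compounds only compound 2, with its 2-methylphenyl, gives a measured number. The step between compound 1 and compound 3, which differ by a single methyl on the chain bound to the ring oxygen, cannot be read, since both values are limits and lengthening that chain shows no readable effect: the limit of > 100000 nM in this assay, at which 2 of the 3 values shown sit.

Compound 2 differs from the other two compounds both in the kind of group on its ring and in that group's place, so these results cannot show which of the two matters in this assay. Also open, going by these compounds, is whether a plain phenyl, or a ring bearing an amine or a carboxylic acid, on the same amide-type nitrogen would give a measured number or another limit.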